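Swapping fluoro for trifluoromethyl in compound 1

The source may report more compounds than this note shows. Statements on the series, on what has been measured and on what is new or still open speak of the compounds shown alone.

In a functional assay on A549 cells (Homo sapiens) for antiproliferative activity, read by MTT assay, with a stated time of 24 h (on this read-out lower numbers stand for stronger inhibition and higher numbers for weaker inhibition), compound 1 (`O=S(=O)(c1ccc(Cl)cc1)n1c(-c2cn(-c3ccccc3)nc2-c2ccc(F)cc2)nc2ccccc21`) gives 3170 nM as its measured value, and compound 2 (`O=S(=O)(c1ccc(Br)cc1)n1c(-c2cn(-c3ccccc3)nc2-c2ccc(F)cc2)nc2ccccc21`) gives 1720 nM in the same test. For the measured compounds named here, these are the only two numbers so far. They lie within the usual scatter of each other, so neither can be ranked against the other.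

Compound 3 (`O=S(=O)(c1ccc(Cl)cc1)n1c(-c2cn(-c3ccccc3)nc2-c2ccc(C(F)(F)F)cc2)nc2ccccc21`) has not yet been measured. It keeps the core of compound 1 and changes one group: trifluoromethyl in place of fluoro on an aromatic carbon. In plain terms, 4-fluorophenyl becomes 4-(trifluoromethyl)phenyl.

Going by the values given here, the only measured step is a 1.8-fold lower number from compound 1 to compound 2 (0.27 log units; within the scatter), with bromo in place of chloro on an aromatic carbon. Among the compounds with values here, that exchange sits at a different place in the molecule and involves different groups, so it is only a loose guide, and no measured compound carries trifluoromethyl. With that single step inside the scatter, no step beyond the scatter is expected in this assay, and neither direction is favoured. The expected step is a 1.1-fold lower number from compound 1 to compound 3 (0.05 log units; within the scatter) as a rough estimate. For compound 3 the estimated value is 2800 nM with an expected range from 1000 nM to 8000 nM in this test.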

Compound 3, half-maximal inhibitory concentration: 2560 nM
Estimate against measurement, compound 3: 1.1-fold (0.04 log units) above, and the stated range covers the measured number.
By their numbers in this assay, from the lowest: compounds 2, 3 and 1 (each within the scatter of the next).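

In this assay, for the compounds shown here, this is the first reading at the 4-fluorophenyl group, and it gives a 1.2-fold lower number from compound 1 to compound 3 (0.09 log units; within the scatter). The earlier step concerned a different place in the molecule, whereas this one shows that fluoro can give way to trifluoromethyl, with 4 heavy atoms in place of 1, on this aromatic carbon, and the two numbers still cannot be told apart; within this pair, the larger group at this position brings no measurable loss or gain in antiproliferative activity. No measured property of these compounds is available to explain this result.

Both groups seen at this position carry no hydrogen-bond donors, no hydrogen-bond acceptors and no net charge, so what an amine or a carboxylic acid would do at the same place remains an open question. Also open, on these data alone, is whether a bromo group on the other aromatic ring, paired with trifluoromethyl here, would read any differently from compound 3 in this assay.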